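The source may hold more compounds than are shown below. What is called first, only, known or untested is meant among the compounds shown, and "the series" means these compounds.

Going by the values given here, in an assay on L cells for inhibition of Protein-serine O-palmitoleoyltransferase porcupine (Mus musculus), read by reporter gene assay, with a stated time of 24 h (on this read-out lower numbers stand for an effect already at smaller amounts and higher numbers for an effect only at larger amounts of compound), compound 1 `O=C(CSc1nc2c(c(=O)n1-c1ccccc1)SCC2)Nc1nc2ccc(Cl)cc2s1` gives 40 nM, the only full number among the three values measured so far. Compound 2 `CN(C)c1ccc(NC(=O)CSc2nc3c(c(=O)n2-c2ccccc2)SCC3)cc1` returns > 1000 nM, which is a limit of the assay rather than a number. Compound 3 `CC(=O)c1ccc(NC(=O)CSc2nc3c(c(=O)n2-c2ccccc2)SCC3)cc1` likewise returns > 1000 nM, again a limit. Both of these changes replace the group on the amide nitrogen: an at least 25-fold higher number from compound 1 to compound 2 (1.39 log units; beyond the scatter) and an at least 25-fold higher number from compound 1 to compound 3 (1.39 log units; beyond the scatter), each beyond the scatter. The step that the two limits leave unreadable from compound 2 to compound 3 cannot be sized because both values sit at the limit of > 1000 nM in this assay, at which 2 of the 3 values shown sit. Compound 4 `COc1ccc(-n2c(SCC(=O)Nc3nc4ccc(Cl)cc4s3)nc3c(c2=O)SCC3)cc1` keeps everything compound 1 has, including the same group on the amide nitrogen, and differs only at the phenyl attached to the shared core: methoxy in place of hydrogen on an aromatic carbon. Among the compounds with values here, none of the measured steps touches this part of the molecule, so they offer no direct guide to the change. With nothing measured on the phenyl, the expectation is a step within the usual scatter, a 1.1-fold higher number from compound 1 to compound 4 (0.05 log units; within the scatter) in this assay. Compound 4 is therefore expected to give about 45 nM, within a range of 15 nM to 150 nM.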

Compound 4, half-maximal effective concentration: 35 nM
Compound 4: middle estimate off by 1.3-fold (0.11 log units), on the high side, within the range that was stated.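

Going by these compounds alone, the phenyl on the shared core is tested here for the first time: in this assay, placing a methoxy on this ring gives a 1.1-fold lower number from compound 1 to compound 4 (0.06 log units; within the scatter). Unlike the earlier changes on the amide nitrogen, whose steps lay beyond the scatter, phenyl to 4-methoxyphenyl leaves the reading within it, so this position, para to a large group, accepts a methoxy with no readable loss of effect. Nothing shown explains why this ring accepts the methoxy.

One group at one position cannot show how far this tolerance extends, for example to a carboxylic acid, an amine or a longer chain such as butoxy on the same ring. On these data alone, it also remains open whether a methoxy would be accepted elsewhere on the phenyl.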